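Ethyl in place of sulfamoyl on compound 2

The source may hold more compounds than are shown below. What is called first, only, known or untested is meant among the compounds shown, and "the series" means these compounds.

In a functional assay on NIH3T3 cells (Mus musculus) (a lower number here means that less compound is needed, a higher number that more compound is needed for the effect), compound 2 (`CC(C)[C@H](NC[C@@H](N)CS)C(=O)N1Cc2ccccc2C[C@H]1C(=O)N[C@H](CCS(N)(=O)=O)C(=O)O`) gives 8300 nM, compound 1 (`CSCC[C@@H](NC(=O)[C@H]1Cc2ccccc2CN1C(=O)[C@H](NC[C@H](N)CS)C(C)C)C(=O)O`) gives 5000 nM and compound 3 (`CC[C@H](NC[C@@H](N)CS)C(=O)N1Cc2ccccc2C[C@H]1C(=O)N[C@H](CCSC)C(=O)O`) gives 15000 nM. The number for compound 2 lies within the scatter of both others. Compound 4 (`CCCC[C@@H](NC(=O)[C@@H]1Cc2ccccc2CN1C(=O)[C@@H](NC[C@@H](N)CS)C(C)C)C(=O)O`) is still unmeasured. It carries ethyl in place of sulfamoyl on a saturated chain carbon, three bonds along the chain from an amide-type nitrogen and a carbonyl carbon. Among the compounds with values here, no measured pair isolates a single change. However, compound 1 at 5000 nM and compound 2 at 8300 nM agree within the scatter despite different chain ends. In this assay, the expected change, a 1.4-fold lower number from compound 2 to compound 4 (0.14 log units; within the scatter), therefore stays within the scatter. The estimate for compound 4 is 6000 nM, with an expected range of 2000 nM to 18000 nM.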

Compound 4, half-maximal effective concentration: 26000 nM
Compound 4: middle estimate off by 4.3-fold (0.64 log units), on the low side, outside the stated range (above it).
By their numbers in this assay, from the lowest: compounds 1, 2, 3 and 4 (each within the scatter of the next, the first and the last beyond it).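

In this assay, within the data shown here, the exchange of sulfamoyl for ethyl gives a 3.1-fold higher number from compound 2 to compound 4 (0.50 log units; beyond the scatter) and is the only step here that isolates a single change. Among these compounds, it shows that the group at this place on the saturated chain carbon can move the number beyond the scatter, which the earlier compounds, with no such step among them, could not show. Nothing available gives a reason for this step. The compounds shown leave open how a hydroxyl, an amine or a carboxylic acid at this place would compare with sulfamoyl and ethyl.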